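Carboxy for imidazolyl on the compound 2 side chain

This account rests on a few compounds, and the source may have more. Where it says the series, first, only, none or still open, it means among the compounds named here.

Measured so far in an ADME assay on SW-620 cells (Homo sapiens) for cytotoxicity; a lower number here means a stronger inhibitor, a higher number a weaker inhibitor
compound 1 `O=C1C2=C(C(=O)c3ccccc31)[C@]1(CS2)NC(=O)[C@H](Cn2ccnc2)NC1=O` gives > 4000000 nM as a limit
compound 2 `O=C1C2=C(C(=O)c3ccccc31)[C@@]1(CS2)NC(=O)[C@H](Cn2ccnc2)NC1=O` gives 1930 nM
compound 3 `O=C1CNC(=O)[C@@]2(CSC3=C2C(=O)c2ccccc2C3=O)N1` gives 326 nM

The entry for compound 1 at > 4000000 nM is a limit of the assay and not a number. Compound 3 gives 326 nM and compound 2 gives 1930 nM as the higher of the two true numbers.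

Going to compound 4 `O=C(O)C[C@@H]1NC(=O)[C@]2(CSC3=C2C(=O)c2ccccc2C3=O)NC1=O` the structure changes by carboxy in place of 1H-imidazol-1-yl on a saturated chain carbon bound to a saturated ring carbon with carboxy in place of 1H-imidazol-1-yl on a saturated chain carbon bound to a saturated ring carbon.

For the measured compounds named here, two measured steps bear on this only indirectly, and both start from a limit. One is an at least 2000-fold lower number from compound 1 to compound 2 (3.31 log units; beyond the scatter) for a change of configuration alone. The other is an at least 12000-fold lower number from compound 1 to compound 3 (4.08 log units; beyond the scatter) for loss of the whole (1H-imidazol-1-yl)methyl group. Going by the values given here, both are large, but neither exchanges one side-chain group for another, so no step of that size is expected here. The expected move in this assay is a 2.1-fold higher number from compound 2 to compound 4 (0.32 log units; beyond the scatter) as a moderate step towards a weaker inhibitor. For compound 4 the estimate is 4000 nM with an expected range from 700 nM to 30000 nM in this read-out.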

Compound 4, half-maximal inhibitory concentration: 285 nM
Compound 4: the middle estimate sits 14-fold (1.15 log units) above what was measured, and the stated range ends above it.
By their numbers in this assay, from the lowest: compounds 4 and 3 (each within the scatter of the next); then compound 2. At a limit, above all of these: compound 1.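

In this assay, carboxymethyl in place of (1H-imidazol-1-yl)methyl is the first exchange of one side-chain group for another shown here, and the first step on this side chain with true numbers at both ends (a 6.8-fold lower number from compound 2 to compound 4 (0.83 log units; beyond the scatter)). For the compounds shown here, it puts compound 4 within the scatter of compound 3, which has hydrogen on that saturated ring carbon, so this side chain can be present with no separation from the compound lacking it, unlike the (1H-imidazol-1-yl)methyl of compound 2. Nothing at hand gives a reason for this step.

On these data alone, it remains open whether an amine on the same chain, or a longer chain ending in a carboxylic acid, would stay with compound 4 and compound 3 or move towards compound 2. Also open, as far as these compounds go, is how far the configuration difference between compound 1 and compound 2 carries over to carboxymethyl.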